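Furan in place of phenyl on the shared core

The compounds below may be only part of what the source reports. "The series", "measured", "known", "first", "only" and "open" are said of these compounds alone.

Measured compounds in a functional assay on NCI-H460 cells (Homo sapiens) for antiproliferative activity, read by MTT assay, with a stated time of 48 h; on this read-out higher numbers stand for weaker inhibition and lower numbers for stronger inhibition:
compound 1 `COc1cc(-c2cccc3nc(-c4ccccc4)oc23)cc(OC)c1OC` gives 6800 nM
compound 2 `COc1cc(-c2cccc3nc(-c4ccc(C)cc4)oc23)cc(OC)c1OC` gives 1900 nM
compound 3 `COc1cc(-c2cccc3nc(-c4cccc(N)c4)oc23)cc(OC)c1OC` gives 2600 nM

Compound 1 stands highest of the three numbers in this assay. Its nearest neighbour is compound 3, reached by a 2.6-fold lower number from compound 1 to compound 3 (0.42 log units; beyond the scatter), and the furthest is compound 2, reached by a 3.6-fold lower number from compound 1 to compound 2 (0.55 log units; beyond the scatter). Between those two, a 1.4-fold higher number from compound 2 to compound 3 (0.14 log units; within the scatter) shows no separation that counts.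

Compound 4 `COc1cc(-c2cccc3nc(-c4ccco4)oc23)cc(OC)c1OC` is not yet measured. It differs from compound 1 in one place: furan-2-yl in place of phenyl on an aromatic carbon. The two measured steps from compound 1 both alter the phenyl at that same carbon of the five-membered ring, by methyl in place of hydrogen and by amino in place of hydrogen, and each gave a modest lowering of the number. Neither exchanges the whole phenyl for a different ring, so they bear on the position only, not on the change itself.

Going by the values given here, with no closer precedent, the step is expected to be small, most likely within the scatter, with a lean toward a lower number. The estimate for compound 4 is 5000 nM, with a range from 1500 nM to 15000 nM, which is expected to mean a 1.4-fold lower number from compound 1 to compound 4 (0.13 log units; within the scatter).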

Compound 4, half-maximal inhibitory concentration: 2600 nM
Beside the measured number, compound 4's estimate is 1.9-fold (0.28 log units) above it; the range from low to high includes it.
By their numbers in this assay, from the lowest: compounds 2, 3 and 4 (each within the scatter of the next); then compound 1.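

In this assay, the position on the five-membered aromatic ring tolerates more than changes on the phenyl: exchanging the entire phenyl for furan-2-yl gives a 2.6-fold lower number from compound 1 to compound 4 (0.42 log units; beyond the scatter). That step is modest, but it shows that a lower number here does not depend on keeping a six-membered ring or on adding a methyl or amino group to it, and the result stands with no change at the digits printed from compound 3 to compound 4 (within the scatter) and a 1.4-fold higher number from compound 2 to compound 4 (0.14 log units; within the scatter), so the furan-2-yl, 3-aminophenyl and 4-methylphenyl compounds cannot be told apart, and only the unsubstituted phenyl of compound 1 stands apart from all three. No supporting measurement is available to say what lies behind this shared level.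

The compounds shown leave open whether thiophen-2-yl, pyridin-2-yl or a saturated ring such as cyclohexyl would sit at the same level as furan-2-yl, and whether a furan ring carrying a methyl or an amino group would lower the number further. They also leave open whether a carboxylic acid or a longer chain on the ring at this position would keep the level seen here.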